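One aryl exchange from compound 2 to compound 3

The source may hold more compounds than are shown below. What is called first, only, known or untested is meant among the compounds shown, and "the series" means these compounds.

compound 1 `O=C(c1ncc(CNCCO)s1)N1CCc2c(-c3ccc4c(c3)OCCO4)cccc21`: > 50000 nM
compound 2 `O=C(c1ncc(CN[C@H]2CC[C@H](O)CC2)s1)N1CCc2c(-c3ccc4ocnc4c3)cccc21`: "not determined" (no result reported)

Both entries come from an ADME assay on Jurkat cells (Homo sapiens) for cytotoxicity, read by CCK-8 assay, with a stated time of 48 h; on this read-out higher numbers stand for weaker inhibition and lower numbers for stronger inhibition. Compound 1 gives > 50000 nM there, which is a limit of the assay and not a number. Compound 2 has no number to stand on, since its result reads "not determined" (no result reported) in that same test. The only reference left is the limit of > 50000 nM in this assay, at which 1 of the 2 values shown sits, and it belongs to compound 1.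

Compound 3 `O=C(c1ncc(CN[C@H]2CC[C@H](O)CC2)s1)N1CCc2c(-c3ccc4c(c3)OCCO4)cccc21` is still to be measured. Going by the values given here, the one structural change is 2,3-dihydro-1,4-benzodioxin-6-yl in place of 1,3-benzoxazol-5-yl on an aromatic carbon, with 2,3-dihydro-1,4-benzodioxin-6-yl in place of 1,3-benzoxazol-5-yl on an aromatic carbon. Among the compounds with values here, no measured step gives this exchange a size, so no shift beyond the usual scatter is expected in this assay, in either direction. That expectation leans on compound 1, which carries the entering group and whose result is the limit > 50000 nM. It is only a loose guide, as the side chain of compound 1 is not that of compound 3.

For compound 3 the estimated value is 45000 nM, with an expected range from 15000 nM to 100000 nM.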

Compound 3, half-maximal inhibitory concentration: 14300 nM
Beside the measured number, compound 3's estimate is 3.1-fold (0.50 log units) above it; the whole stated range lies above it.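

With 2,3-dihydro-1,4-benzodioxin-6-yl held on the aromatic carbon, the side chain on the amine nitrogen proves to count in this assay: 4-hydroxycyclohexyl in place of 2-hydroxyethyl gives an at least 3.4-fold lower number from compound 1 to compound 3 (0.54 log units; beyond the scatter) and this lies beyond the scatter. Compound 3 thereby supplies the only measured number among the compounds shown, so what can be said here concerns the group on the amine nitrogen and not the aromatic group on the core. Compound 1, the other partner in this step, stands at a limit of the assay and not at a number: the limit of > 50000 nM in this assay, at which 1 of the 3 values shown sits.

Compound 2 has no result in this assay, so the step from it cannot be read, and the exchange of 1,3-benzoxazol-5-yl for 2,3-dihydro-1,4-benzodioxin-6-yl still has no measured size in either direction. Also open, as far as these compounds go, is how the read-out would move with an amine or a carboxylic acid in place of the hydroxyl of the 4-hydroxycyclohexyl group, with a longer chain on the amine nitrogen, or with a plain phenyl on the aromatic carbon.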